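Aryl thioether semicarbazones in a mouse whole-animal read-out

This account rests on a few compounds, and the source may have more. Where it says the series, first, only, none or still open, it means among the compounds named here.

Compound 1 `NC(=O)N/N=C/c1ccc(Sc2ccccc2)cc1`: in a functional assay on the whole organism with Mus musculus as the target, with a stated time of 1 h (on this read-out higher numbers stand for an effect only at larger amounts of compound and lower numbers for an effect already at smaller amounts), compound 1 reaches only the assay limit > 46 mg/kg.
Compound 2 `NC(=O)N/N=C/c1ccc(Sc2ccc(F)cc2)cc1`: in this assay compound 2 reaches only the assay limit > 120 mg/kg.
Compound 3 `NC(=O)N/N=C/c1ccc(Sc2ccc(Cl)cc2)cc1`: in this assay compound 3 reaches only the assay limit > 120 mg/kg.

Compound 3 therefore stands at a limit rather than at a number; it sits at the limit of > 120 mg/kg in this assay, at which 2 of the 3 values shown sit, while the remaining compound sits at the limit of > 46 mg/kg in this assay, at which 1 of the 3 values shown sits. The three steps among the measured compounds, a step that the two limits leave unreadable from compound 1 to compound 2, a step that the two limits leave unreadable from compound 1 to compound 3 and a step that the two limits leave unreadable from compound 2 to compound 3, are all hidden behind these limits, so no size can be read for any of them.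

Compound 4 `Cc1ccc(Sc2ccc(/C=N/NC(N)=O)cc2)cc1` differs from compound 3 by methyl in place of chloro on an aromatic carbon. Going by the values given here, none of the measured steps concerns a methyl group, and the chloro and fluoro steps that come closest are themselves unreadable. Among the compounds with values here, the measured material thus offers no step of known size that bears on this change; all it shows is that every member so far has stayed at a limit in this assay.

For compound 4 the expectation is consequently that it will again return a limit, with a step that the limit leaves unreadable from compound 3 to compound 4 expected to be within the scatter. The estimate for compound 4 in this assay is 150 mg/kg, in the range 50 mg/kg to 450 mg/kg.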

Compound 4, dose for half-maximal effect: > 300 mg/kg
Compound 4: only a limit was reported (the forecaster's own chance of this, stated with the estimate: 80%); middle value at least 2.0-fold (0.30 log units) from the limit.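

Going by these compounds alone, compound 4, like compound 1, compound 2 and compound 3, stands only at a limit in this assay, so no step from any of them to compound 4 can be read. The compounds shown leave open what dose for half-maximal effect any member reaches in this assay, and whether hydrogen, fluoro, chloro or methyl at that place makes any difference.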